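Carboxy in place of amino on the shared core: compound 4

The source may report more compounds than this note shows. Statements on the series, on what has been measured and on what is new or still open speak of the compounds shown alone.

Measured so far in a functional assay on SK-OV-3 cells (Homo sapiens) for inhibition, read by CCK-8 assay, with a stated time of 70 h; a lower number here means a stronger inhibitor, a higher number a weaker inhibitor:
compound 1 `O=[N+]([O-])c1cccc(COc2ccc(OCCOCCNC3CCCC3)cc2)c1` gives 15400 nM
compound 2 `COc1ccc(OCCOCCNC2CCCC2)cc1` gives 99100 nM
compound 3 `Nc1cccc(COc2ccc(OCCOCCNC3CCCC3)cc2)c1` gives 10800 nM

Compound 3 gives the lowest of the three numbers, but compound 1 sits within the scatter of it: a 1.4-fold lower number from compound 1 to compound 3 (0.15 log units; within the scatter). Only compound 2 is clearly apart, a 9.2-fold lower number from compound 2 to compound 3 (0.96 log units; beyond the scatter), and the mirror step a 6.4-fold higher number from compound 1 to compound 2 (0.81 log units; beyond the scatter) tells the same thing: the substituted phenyl on the chain carbon bound to the aryl oxygen is what carries the gain over compound 2, while swapping the group on that ring between nitro and amino barely registers.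

Compound 4 `O=C(O)c1cccc(COc2ccc(OCCOCCNC3CCCC3)cc2)c1` differs from compound 3 in one place: carboxy in place of amino on an aromatic carbon. Among the compounds with values here, no measured step shows a carboxy group anywhere, so the only bearing precedent is the nitro-to-amino change on the same ring carbon, which stayed within the scatter. On that basis the expected step in this assay from compound 3 to compound 4 is small, a 1.4-fold higher number from compound 3 to compound 4 (0.14 log units; within the scatter), with a lean toward a higher number and no confident direction beyond the scatter. The estimate for compound 4 in this assay is therefore 15000 nM, within a range of 5000 nM to 50000 nM.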

Compound 4, half-maximal inhibitory concentration: > 100000 nM
Compound 4: only a limit was reported (the forecaster's own chance of this, stated with the estimate: 10%); middle value at least 6.6-fold (0.82 log units) away from the limit.
By their numbers in this assay, from the lowest: compounds 3 and 1 (each within the scatter of the next); then compound 2. At a limit, above all of these: compound 4.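

In this assay compound 4 gives > 100000 nM, which is a limit of the assay and not a number. This ring carbon is therefore not indifferent to its substituent, as the nitro and amino pair alone suggested: those two stay within the scatter of each other, while carboxy gives an at least 9.2-fold higher number from compound 3 to compound 4 (0.96 log units; beyond the scatter) and an at least 6.4-fold higher number from compound 1 to compound 4 (0.81 log units; beyond the scatter). The remaining step, a number no lower from compound 2 to compound 4 (the limit leaves the size open), cannot be read for size, so whether the 3-carboxyphenyl group keeps any of the gain seen with the nitro and amino analogues stays undecided.

From the compounds shown here alone, the series holds no methyl ester or primary carboxamide on this aromatic carbon, so it remains open whether the sharp rise in the number belongs to the carboxylic acid itself or to any carbonyl-bearing group placed there. Also open, going by these compounds, is how far the rise extends, and whether a carboxylic acid on another carbon of the same ring, or one set apart from the ring by a methylene, would behave the same way.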